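From cyclohexyl to 4-bromophenyl on the sulfur chain

The source may hold more compounds than are shown below. What is called first, only, known or untested is meant among the compounds shown, and "the series" means these compounds.

Of the compounds shown here, three with a shared core have been measured in an ADME assay on GES1 cells (Homo sapiens) for inhibition, read by MTT assay, with a stated time of 72 h; a higher number here means a weaker inhibitor, a lower number a stronger inhibitor. Here compound 1 (`Cc1cc(Nc2cc(-c3ccccc3)[nH]n2)n2nc(SCCc3ccccc3)nc2n1`) gives 37400 nM, and compound 2 (`Cc1cc(Nc2cc(-c3ccccc3)[nH]n2)n2nc(SCc3c(Cl)cccc3Cl)nc2n1`) gives 39600 nM.

Compound 3 (`Cc1cc(Nc2cc(-c3ccccc3)[nH]n2)n2nc(SCC3CCCCC3)nc2n1`) is known only as a limit, > 50000 nM, and not as an exact number.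

Compound 4 (`Cc1cc(Nc2cc(-c3ccccc3)[nH]n2)n2nc(SCc3ccc(Br)cc3)nc2n1`) has not yet been measured. It differs from compound 3 on a saturated chain carbon bound to a sulfur, where 4-bromophenyl replaces cyclohexyl: 4-bromophenyl in place of cyclohexyl on a saturated chain carbon bound to a sulfur.

Among the measured compounds shown here, three measured steps bear on this change. Exchanging one aromatic group for another, 2,6-dichlorophenyl in place of benzyl, gives a 1.1-fold higher number from compound 1 to compound 2 (0.02 log units; within the scatter), which is within the scatter. Placing cyclohexyl on that carbon gives an at least 1.3-fold higher number from compound 1 to compound 3 (0.12 log units; that floor lies within the scatter) and an at least 1.2-fold higher number from compound 2 to compound 3 (0.10 log units; that floor lies within the scatter), and both of these floors also lie within the scatter.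

Compound 4 carries an aromatic group, as does compound 2 at 39600 nM, so a value in the same region is expected. The expected change, an at least 1.2-fold lower number from compound 3 to compound 4 (0.09 log units; that floor lies within the scatter), is no clear step beyond the scatter. For compound 4 the estimated value is 40000 nM, with an expected range of 22000 nM to 65000 nM.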

Compound 4, half-maximal inhibitory concentration: 39300 nM
The estimate for compound 4 lay 1.0-fold (0.01 log units) above the measured number, within the range that was stated.
By their numbers in this assay, from the lowest: compounds 1, 4 and 2 (each within the scatter of the next). At a limit, above all of these: compound 3.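

In this assay, 4-bromophenyl on a saturated chain carbon bound to a sulfur gives a 1.0-fold lower number from compound 2 to compound 4 (0.00 log units; within the scatter) and a 1.1-fold higher number from compound 1 to compound 4 (0.02 log units; within the scatter), so compound 1, compound 2 and compound 4 cannot be told apart, even though the aromatic groups carry bromine, two chlorines or no halogen at all. Placing 4-bromophenyl in place of the non-aromatic cyclohexyl ring gives an at least 1.2-fold lower number from compound 3 to compound 4 (0.10 log units; that floor lies within the scatter), so this floor does not establish a real difference between the aromatic ring and cyclohexyl. Compound 3 is known only as a limit of the assay, and among these compounds it stands alone in this: the limit of > 50000 nM in this assay, at which 1 of the 4 values shown sits.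

What this assay would give with an amine, a carboxylic acid or a pyridine ring at this position remains open, since every group shown here is built on a carbon-only ring. Also open, from the compounds shown here alone, is the true distance between compound 3 and the other three compounds, which an exact value for compound 3 would be needed to settle.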